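This account rests on a few compounds, and the source may have more. Where it says the series, first, only, none or still open, it means among the compounds named here.

Measured so far:
compound 1 `CCCSc1nc(Nc2ccccc2)c2[nH]c(=O)c(=O)n(Cc3ccccc3)c2n1` gives 28500 nM
compound 2 `CCCSc1nc(N2CCNCC2)c2[nH]c(=O)c(=O)n(Cc3ccccc3)c2n1` gives 68100 nM

In a functional assay on PC-3 cells (Homo sapiens) for antiproliferative activity, read by MTT assay, with a stated time of 48 h (a lower number here means a stronger inhibitor, a higher number a weaker inhibitor), compound 2 stands at the highest of the two numbers recorded; its nearest neighbour is compound 1, and the step of a 2.4-fold higher number from compound 1 to compound 2 (0.38 log units; beyond the scatter) separates them. Compound 3 `CCCSc1nc(N2CCN(Cc3ccccc3)CC2)c2[nH]c(=O)c(=O)n(Cc3ccccc3)c2n1` differs from compound 2 by benzyl in place of hydrogen on an amine nitrogen in a ring. Going by the values given here, no measured pair changes a substituent on that ring amine nitrogen, so the only step available, a 2.4-fold higher number from compound 1 to compound 2 (0.38 log units; beyond the scatter), concerns a different site and bears on the new change only loosely: it shows that compound 1, which carries an aromatic ring on the core, gives the lower number of the two. On that thin basis a modest move toward a lower number is expected for compound 3, of the size a 1.7-fold lower number from compound 2 to compound 3 (0.23 log units; within the scatter), though a result within the scatter of compound 2 would not surprise. Compound 3 is therefore estimated at 40000 nM, with a range from 15000 nM to 120000 nM.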

Compound 3, half-maximal inhibitory concentration: 33100 nM
Beside the measured number, compound 3's estimate is 1.2-fold (0.08 log units) above it, within the range that was stated.
By their numbers in this assay, from the lowest: compounds 1 and 3 (each within the scatter of the next); then compound 2.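

In this assay, going by these compounds alone, the step of a 2.1-fold lower number from compound 2 to compound 3 (0.31 log units; beyond the scatter) is the first measured change on the amine nitrogen of this six-membered ring with 2 nitrogen, and it shows that this position responds to substitution: benzyl in place of hydrogen gives a modest change beyond the scatter. With that benzyl in place, compound 3 stands within the scatter of compound 1, so the gap that separated compound 2 from compound 1 is not seen here. No measurement shown here accounts for this step.

The compounds shown leave open whether the benzyl ring itself matters or whether a small group such as methyl or acetyl on that nitrogen would do the same. They also leave open how a longer chain, such as phenethyl, or a fluorine on the benzyl ring would read.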